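A Second Chloro Group on Two Related Purine Cores

The source may report more compounds than this note shows. Statements on the series, on what has been measured and on what is new or still open speak of the compounds shown alone.

The measured compounds and their results:

Compound 1, `ClCc1ccccc1Cn1cnc2c(Cl)nc(Cl)nc21`, gives 5620 nM in a functional assay on SF-539 cells (Homo sapiens) for cytotoxicity, read by sulforhodamine B assay, with a stated time of 48 h; on this read-out lower numbers stand for higher toxicity in this test and higher numbers for lower toxicity in this test.
Compound 2, `ClCc1ccccc1Cn1cnc2c(Cl)ncnc21`, gives 55000 nM in this assay.
Compound 3, `ClCc1ccccc1Cn1cnc2ncnc(Cl)c21`, gives 12000 nM in this assay.

Compound 2 and compound 3 are built from the same atoms joined differently; the difference between the two cores is not broken down here. What the two values show is that compound 3 gives the lower number of the pair in this assay.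

Compound 1 is compound 2 with one addition: chloro in place of hydrogen on an aromatic carbon. This single change produced a 9.8-fold lower number from compound 2 to compound 1 (0.99 log units; beyond the scatter), so the added chloro group went along with a clearly lower number.

Compound 4, `ClCc1ccccc1Cn1cnc2nc(Cl)nc(Cl)c21`, has not yet been measured. It stands to compound 3 exactly as compound 1 stands to compound 2: chloro in place of hydrogen on an aromatic carbon. The place of the new group is described in the same words for both pairs, so this is the same change made on a different core.

Because the same change gave a 9.8-fold lower number from compound 2 to compound 1 (0.99 log units; beyond the scatter), a step of similar size is expected from compound 3 to compound 4, namely an 8.0-fold lower number from compound 3 to compound 4 (0.90 log units; beyond the scatter). Going by the values given here, only one earlier example of this change exists, and the two cores differ, so the expected range is kept wide. Compound 4 is therefore estimated to give about 1500 nM in this assay, likely between 500 nM and 5000 nM.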

Compound 4, concentration lethal to 50% of the cells: 8310 nM
Estimate against measurement, compound 4: 5.5-fold (0.74 log units) below, and the stated range ends below it.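

In this assay, going by these compounds alone, chloro in place of hydrogen on the second core gave a 1.4-fold lower number from compound 3 to compound 4 (0.16 log units; within the scatter), so on this core the change produced no step that can be told apart from the ordinary spread of repeated measurements. Set side by side, the two examples show that the same change did not carry over from one core to the other at the same size: the same change on two cores in this assay, a 9.8-fold lower number (0.99 log units; beyond the scatter) from compound 2 to compound 1 and a 1.4-fold lower number (0.16 log units; within the scatter) from compound 3 to compound 4, 6.8-fold (0.83 log units) apart, beyond the scatter of two such steps. Within the data shown here, this shows that a step seen on one of these cores was not a reliable guide to the step on the other, but with only two pairs it does not show what in the cores separates the two results, nor what the change would do on any further core.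

As far as these compounds go, only chloro and hydrogen appear at this place on the ring, so it remains open whether a bromo group, a methoxy group or an amine there would give a large step on one core and a negligible step on the other, as chloro does. From the compounds shown here alone, whether the gap between the two steps would also appear in any test other than this assay remains open too.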